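Working notes: from compound 3 to compound 4

The source may report more compounds than this note shows. Statements on the series, on what has been measured and on what is new or still open speak of the compounds shown alone.

Measured in a functional assay on the whole organism with Mus musculus as the target (on this read-out higher numbers stand for an effect only at larger amounts of compound and lower numbers for an effect already at smaller amounts), as follows
- compound 1 `CN1C(=O)CCC1(O)c1cccc(C(F)(F)F)c1` gives 93.8 mg/kg as a number
- compound 2 `CCCN1C(=O)CCC1(O)c1cccc(C(F)(F)F)c1` gives > 200 mg/kg as a limit
- compound 3 `CCC(C)NC(=O)CCC(=O)c1cccc(C(F)(F)F)c1` gives > 200 mg/kg as a limit

Compound 3 reads > 200 mg/kg in this assay and this is a limit, not a number. It sits on the limit of > 200 mg/kg in this assay, at which 2 of the 3 values shown sit, and so offers only a bound to start from.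

Compound 4 `CN1CCN(C(=O)CCC(=O)c2cccc(C(F)(F)F)c2)CC1` carries one change from compound 3, 4-methylpiperazin-1-yl in place of (sec-butyl)amino on a carbonyl carbon and the change is 4-methylpiperazin-1-yl in place of (sec-butyl)amino on a carbonyl carbon.

Going by the values given here, the one measured step is an at least 2.1-fold higher number from compound 1 to compound 2 (0.32 log units; beyond the scatter) and it goes beyond the scatter towards the higher number. That step bears only weakly here, since it lies at another place on another core. Among the compounds with values here, no measured step covers a change on this carbonyl carbon, so its size cannot be carried over directly. With no better guide, no step beyond the scatter is expected in this assay and no direction is favoured with confidence.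

The expected change is an at least 1.1-fold lower number from compound 3 to compound 4 (0.04 log units; that floor lies within the scatter) with the reading staying near the limit. For compound 4 the estimate is 180 mg/kg with an expected range of 90 mg/kg to 360 mg/kg and a report of a limit alone remains quite possible.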

Compound 4, dose for half-maximal effect: > 50 mg/kg
Compound 4: only a limit was reported; the forecaster's own chance of this, stated with the estimate: 55%; the middle value is on the limit's open side.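

In this assay compound 3 gives > 200 mg/kg, which is a limit. Going by these compounds alone, compound 4 gives > 50 mg/kg, which is also a limit, so no step between compound 3 and compound 4 can be read. The compounds shown leave open whether 4-methylpiperazin-1-yl in place of (sec-butyl)amino on a carbonyl carbon shifts the read-out, and in which direction.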